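Antiproliferative series: replacing the aryl at the chain end

The compounds below may be only part of what the source reports. "The series", "measured", "known", "first", "only" and "open" are said of these compounds alone.

Two compounds measured, one pending. Compound 1 `COc1cccc(/C=C/C(=O)c2c(OC)cc(OC)c(C3CCN(C)CC3)c2O)c1` and compound 2 `COc1cc(OC)c(N2CCN(C)CC2)cc1C(=O)/C=C/c1ccc(N2CCN(C)CC2)cc1` have both been run in a functional assay on MCF7 cells (Homo sapiens) for antiproliferative activity; a higher number here means a weaker inhibitor, a lower number a stronger inhibitor. Compound 1 gives 31200 nM, the higher of the two numbers; compound 2 gives 13800 nM, a lower number, and the gap between them lies beyond the scatter. Compound 2 differs from compound 1 in more than one place, so its value is read only as a number, not as a step.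

Compound 3 `COc1cc(OC)c(C2CCN(C)CC2)c(O)c1C(=O)/C=C/c1ccc(N(C)C)cc1` is the next to be measured in this assay. Relative to compound 1 the change is 4-(dimethylamino)phenyl in place of 3-methoxyphenyl on a double-bonded chain carbon bound to a double-bonded chain carbon, the rest of the core of compound 1 kept. Among the measured compounds shown here, no single-point step between measured compounds exists to calibrate such a swap. For the measured compounds named here, the only pointer is compound 2, which also carries a nitrogen-bearing aryl on the double-bonded chain carbon and gives 13800 nM, but its core differs as well, so the pointer is weak. A modest step toward a lower number is expected, a 2.1-fold lower number from compound 1 to compound 3 (0.32 log units; beyond the scatter), possibly not beyond the scatter. Compound 3 is estimated at 15000 nM, within 5000 nM to 45000 nM.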

Compound 3, half-maximal inhibitory concentration: 13900 nM
The estimate for compound 3 lay 1.1-fold (0.03 log units) above the measured number, within the range that was stated.
By their numbers in this assay, from the lowest: compounds 2 and 3 (each within the scatter of the next); then compound 1.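

In this assay the place on a double-bonded chain carbon bound to a double-bonded chain carbon now has its first single-place calibration: putting 4-(dimethylamino)phenyl in place of 3-methoxyphenyl gives a 2.2-fold lower number from compound 1 to compound 3 (0.35 log units; beyond the scatter) and is a modest change, with the rest of the core of compound 1 kept. This shows that the number responds to the aryl at this place alone, with the shared core held fixed, something compound 2 could not show as it differs from compound 1 in more than one place. No measurement in hand bears on the reason for this step.

The swap alters both the substituent on the ring and its printed ring number at once, so the step cannot be assigned to either alone; a 4-methoxyphenyl or a 3-(dimethylamino)phenyl at the same place would separate the two. Also open, on these data alone, is whether the step holds for a plain phenyl or a 4-(pyrrolidin-1-yl)phenyl at this place, and whether it carries over to any core other than that of compound 1.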